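The compounds below may be only part of what the source reports. "The series", "measured", "known", "first", "only" and "open" are said of these compounds alone.

Compound 1 `COc1ccc(/C=C\c2cc(OC)c(OC)c(OC)c2)cc1OCc1ccc(CN2CC[C@H](C(=O)O)C2)cc1` carries a 3-carboxypyrrolidin-1-yl group on a saturated chain carbon bound to an aromatic carbon. In a functional assay on MC-38 cells (Mus musculus) for antiproliferative activity, read by CCK-8 assay, with a stated time of 48 h (a lower number here means a stronger inhibitor, a higher number a weaker inhibitor), compound 1 gives > 10000 nM, which is a limit of the assay rather than a number. Compound 2 `COc1ccc(/C=C\c2cc(OC)c(OC)c(OC)c2)cc1OCc1ccc(CN2CC(C(=O)O)C2)cc1` differs from it only in bearing 3-carboxyazetidin-1-yl in place of 3-carboxypyrrolidin-1-yl on that carbon. In this assay compound 2 gives > 10000 nM, again a limit and not a number. The step that the two limits leave unreadable from compound 1 to compound 2 therefore cannot be read, since (the limit of > 10000 nM in this assay, at which 2 of the 2 values shown sit). Going by the values given here, compound 2 thus stands only at a limit, and the one further value shown is a limit as well. Compound 3 `COc1ccc(/C=C\c2cc(OC)c(OC)c(OC)c2)cc1OCc1ccc(C=O)cc1` brings the next change: formyl in place of (3-carboxyazetidin-1-yl)methyl on an aromatic carbon. No measured step bears on this change, as the only step shown is unreadable. The expected step of an at least 1.2-fold lower number from compound 2 to compound 3 (0.09 log units; that floor lies within the scatter) therefore rests on the limits alone and is estimated as none clearly beyond the scatter. For compound 3 in this assay the estimate is 8000 nM, with a range from 800 nM to 40000 nM.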

Compound 3, half-maximal inhibitory concentration: 900 nM
Compound 3: the middle estimate sits 8.9-fold (0.95 log units) above what was measured; the range from low to high includes it.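

In this assay, going by these compounds alone, compound 3 gives 900 nM, the first value here that is a number and not a limit, so the shared core can register in this read-out when the group on this aromatic carbon, para to a large group, is changed. Formyl in place of (3-carboxyazetidin-1-yl)methyl gives an at least 11-fold lower number from compound 2 to compound 3 (1.04 log units; beyond the scatter), and formyl in place of (3-carboxypyrrolidin-1-yl)methyl gives an at least 11-fold lower number from compound 1 to compound 3 (1.04 log units; beyond the scatter). Both sizes are floors and not exact steps, because compound 1 and compound 2 each stand at a limit: the limit of > 10000 nM in this assay, at which 2 of the 3 values shown sit.

Each change removes the ring nitrogen, the ring and the carboxylic acid together, so the compounds shown do not tell which of these parts accounts for the step. Going by these compounds, whether a hydroxymethyl group or a simple dimethylaminomethyl group on this carbon would give a number close to that of compound 3 also remains open.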